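A few compounds are considered here, and "the series" means these few. Any claim that something is new, unique, unknown or untested is made for them only; others in the source may bear on it.

Measured so far in a functional assay on 143B cells (Homo sapiens) for inhibition, read by CCK-8 assay, with a stated time of 72 h, tested at 1 uM; on this read-out higher numbers stand for more inhibition at the one concentration tested (going by the name of the read-out) and lower numbers for less inhibition:
- compound 1 `COc1ccccc1N1C(=O)C(C)SC1c1cccc(C(=O)NCCCCc2ccccc2)c1`: 61%
- compound 2 `COc1ccc(C)cc1N1C(=O)CSC1c1cccc(C(=O)NCCCCc2ccccc2)c1`: 29%

Compound 2 stands lowest of the two numbers; its nearest neighbour is compound 1, which sits higher by a margin beyond the usual scatter of this read-out. Among the compounds with values here, no single-point step between the two measured compounds is available, since they differ in more than one place, so their two values can only be set side by side.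

Compound 3 `COc1cccc(OC)c1N1C(=O)CSC1c1cccc(C(=O)NCCCCc2ccccc2)c1` is not yet measured. It differs from compound 2 in one place: 2,6-dimethoxyphenyl in place of 2-methoxy-5-methylphenyl on an amide-type nitrogen in a ring. The change sits on the amide-type nitrogen in the ring, so the rest of the shared core is untouched. Within the data shown here, nothing among the measured compounds isolates this change, so no step can be read off for it. The expectation is a modest rise in this assay, estimated as a number 11 percentage points higher from compound 2 to compound 3 (beyond the scatter), with wide uncertainty in both directions. For compound 3 the estimated value in this assay is 40%, with a range from 15% to 65%.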

Compound 3, a percentage reported as inhibition, at one concentration (the size of the read-out at that concentration, not a potency): 31%
Estimate against measurement, compound 3: 9 percentage points above; the measured number falls inside the stated range.
By their numbers in this assay, from the lowest: compounds 2 and 3 (each within the scatter of the next); then compound 1.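

In this assay, within the data shown here, the exchange of 2-methoxy-5-methylphenyl for 2,6-dimethoxyphenyl provides the first single-place reading on the amide-type nitrogen in the ring: a number 2 percentage points higher from compound 2 to compound 3 (within the scatter). In this pair, the entering group's added oxygen and added hydrogen-bond acceptor come with a number that stays within the scatter, so this exchange at this position does not separate compound 2 and compound 3. No measured information is available to explain why these two aryl groups read alike.

Compound 2 and compound 3 each differ in more than one place from compound 1, which gives 61%, so how much of that number belongs to its aryl group and how much to its other difference remains unresolved. On these data alone, it also remains open whether a phenyl group bearing an amine or a carboxylic acid, or a longer alkyl chain in place of the aryl group on this nitrogen, would give a number beyond the scatter of this pair.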